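The source may report more compounds than this note shows. Statements on the series, on what has been measured and on what is new or still open speak of the compounds shown alone.

Measured compounds:
compound 1 `Cc1nc(N)c2nc(O)n(Cc3ccccc3)c2n1`, 3 mg/kg
compound 2 `CCCCCNc1nc(N)c2nc(O)n(Cc3ccccc3)c2n1`, 0.3 mg/kg
compound 3 `Nc1ncnc2c1nc(O)n2Cc1ccccc1`, 30 mg/kg

In a functional assay on the whole organism for activation, with Mus musculus as the target (a higher number here means that more compound is needed for the effect, a lower number that less compound is needed), compound 3 gives the highest number of the three: a 10-fold higher number from compound 1 to compound 3 (1.00 log units; beyond the scatter) and a 100-fold higher number from compound 2 to compound 3 (2.00 log units; beyond the scatter) both lead to it. Compound 4 `Nc1ncnc2c1nc(S)n2Cc1ccccc1` differs from compound 3 by sulfanyl in place of hydroxy on an aromatic carbon. For the measured compounds named here, no measured step touches this position; the two steps that are known, a 10-fold higher number from compound 1 to compound 3 (1.00 log units; beyond the scatter) and a 100-fold higher number from compound 2 to compound 3 (2.00 log units; beyond the scatter), concern the group on a different aromatic carbon and offer no guide to exchanging hydroxy for sulfanyl. With one heavy atom swapped for one and the donor and acceptor pattern unchanged, no step beyond the scatter is expected in either direction. Compound 4 is therefore estimated at 30 mg/kg, range 10 mg/kg to 100 mg/kg, meaning an expected step of no change at the digits printed from compound 3 to compound 4 (within the scatter).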

Compound 4, minimum effective dose: > 30 mg/kg
Compound 4 was reported as a limit (the forecaster's own chance of this, stated with the estimate: 20%); the middle value lies on the limit itself.
By their numbers in this assay, from the lowest: compound 2; then compound 1; then compound 3.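

In this assay compound 4 gives > 30 mg/kg, which is a limit and not a number. For the compounds shown here, this is the first reading at the aromatic carbon between two ring nitrogen atoms: sulfanyl in place of hydroxy gives a number no lower from compound 3 to compound 4 (the limit leaves the size open), so the exchange brings no gain on the unsubstituted core. How far the number rises, if at all, cannot be read.

Open, on these data alone, is how an amine or a methoxy group would read at this carbon. Also open, as far as these compounds go, is whether sulfanyl reads the same with the pentylamino group of compound 2 on the core.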